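Swapping the Ring on the Hydrazide Carbonyl

This account rests on a few compounds, and the source may have more. Where it says the series, first, only, none or still open, it means among the compounds named here.

Measured in an ADME assay on NIH3T3 cells (Mus musculus) for cytotoxicity, read by LDH release, with a stated time of 48 h; on this read-out lower numbers stand for stronger inhibition and higher numbers for weaker inhibition:
compound 1 `O=C(COc1c(F)cc(C(=O)c2ccc(F)cc2)cc1Cl)NNC(=O)c1ccc(=O)oc1` gives 89800 nM
compound 2 `Cn1cnc(C(=O)NNC(=O)COc2ccc(C(=O)c3ccccc3)cc2)c1` gives 97400 nM
compound 3 `Cc1ccc(C(=O)c2cc(F)c(OCC(=O)NNC(=O)c3ccc(=O)oc3)c(Cl)c2)cc1` gives 32100 nM

Compound 2 stands at the high end of these three numbers; compound 1 lies within the usual scatter of it, while compound 3 sits lower, beyond the scatter. For the measured compounds named here, the one measured step, a 2.8-fold lower number from compound 1 to compound 3 (0.45 log units; beyond the scatter), is modest.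

Compound 4 `O=C(COc1ccc(C(=O)c2ccccc2)cc1)NNC(=O)c1ccc(=O)oc1` is not yet measured. It differs from compound 2 in a single place: a group of 7 heavy atoms (5 carbon, 2 oxygen; one six-membered aromatic ring with 1 hetero atom) in place of a group of 6 heavy atoms (4 carbon, 2 nitrogen; one five-membered aromatic ring with 2 hetero atoms), on a carbonyl carbon. Going by the values given here, no measured step changes this part of the molecule, so the step from compound 2 to compound 4 has no direct counterpart. What can be said is that compounds 1 and 3 already carry the entering group and give numbers near or somewhat below compound 2, whereas compound 2 with the leaving group gives the highest of the three.

On that footing the step is expected to be small, a 1.3-fold lower number from compound 2 to compound 4 (0.11 log units; within the scatter), within or barely beyond the scatter, leaning lower. Compound 4 is therefore estimated at 75000 nM, with a range from 30000 nM to 190000 nM.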

Compound 4, half-maximal inhibitory concentration: 88200 nM
Compound 4: middle estimate off by 1.2-fold (0.07 log units), on the low side, within the range that was stated.
By their numbers in this assay, from the lowest: compound 3; then compounds 4, 1 and 2 (each within the scatter of the next).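

For the compounds shown here, this is the first measured step that changes only the group on the carbonyl carbon whose other neighbour is the amide-type nitrogen. In this assay, placing the six-membered aromatic ring with one hetero atom there in place of 1-methyl-1H-imidazol-4-yl gives a 1.1-fold lower number from compound 2 to compound 4 (0.04 log units; within the scatter), so the read-out does not separate these two groups on the core of compound 2. The data offer no explanation for this close match.

On these data alone, it remains open whether a phenyl ring, a pyridine ring or a short alkyl chain on this carbonyl carbon would also leave the number unchanged. As far as these compounds go, it is equally open whether 1-methyl-1H-imidazol-4-yl and the entering group would also match on the cores of compound 1 and compound 3, which carry fluoro and chloro substituents.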